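Swapping the aryl group on the shared core

This account rests on a few compounds, and the source may have more. Where it says the series, first, only, none or still open, it means among the compounds named here.

Of the compounds shown here, three with a shared core have been measured in an assay for inhibition of Intestinal-type alkaline phosphatase (Homo sapiens), read by spectrophotometry, with stated times of 10 min and 20 min; on this read-out higher numbers stand for weaker inhibition and lower numbers for stronger inhibition. Compound 1 `COc1cccc(/C=C2\NS(=O)(=O)c3ccccc3C2=O)c1` gives 1040 nM, compound 2 `O=C1/C(=C/c2cccc(Br)c2)NS(=O)(=O)c2ccccc21` gives 2550 nM, and compound 3 `O=C1/C(=C/c2ccc(Cl)cc2Cl)NS(=O)(=O)c2ccccc21` gives 4960 nM. Compound 2 therefore stands second highest of the three, within the scatter of compound 3 and beyond it from compound 1. Among the measured compounds shown here, the only single-place step known is a 2.5-fold higher number from compound 1 to compound 2 (0.39 log units; beyond the scatter). Compound 4 `Cc1ccccc1/C=C1\NS(=O)(=O)c2ccccc2C1=O` differs from compound 2 by 2-methylphenyl in place of 3-bromophenyl on a double-bonded chain carbon bound to a double-bonded ring carbon. For the measured compounds named here, no measured step bears directly on this change; the one known step shows that swapping a group on this aryl ring moves the number modestly. A modest shift in either direction, or none beyond the scatter, is therefore expected, and compound 4 is estimated at 2200 nM, between 700 nM and 7000 nM, a step of a 1.2-fold lower number from compound 2 to compound 4 (0.06 log units; within the scatter).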

Compound 4, half-maximal inhibitory concentration: 3750 nM
The estimate for compound 4 lay 1.7-fold (0.23 log units) below the measured number; the range from low to high includes it.
By their numbers in this assay, from the lowest: compound 1; then compounds 2, 4 and 3 (each within the scatter of the next).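

Putting 2-methylphenyl in place of 3-bromophenyl on a double-bonded chain carbon bound to a double-bonded ring carbon gives a 1.5-fold higher number from compound 2 to compound 4 (0.17 log units; within the scatter), so these two aryl groups cannot be told apart on this read-out. Among the compounds shown here, this step involves the whole aryl group, whereas the earlier step changed only one group on the ring. Nothing measured here offers an explanation for the result. Still open, going by these compounds, is whether an aryl ring carrying an amine or a carboxylic acid would move the number beyond the scatter. On these data alone, how a plain phenyl group would compare also remains unknown.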